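From 3-methoxyphenyl to 4-methoxyphenyl: compound 1 and compound 4

A few compounds are considered here, and "the series" means these few. Any claim that something is new, unique, unknown or untested is made for them only; others in the source may bear on it.

Going by the values given here, in an ADME assay on L02 cells (Homo sapiens) for cytotoxicity, read by MTT assay, with a stated time of 72 h (a lower number here means a stronger inhibitor, a higher number a weaker inhibitor), compound 1 (`C=CC(=O)Nc1cccc(Oc2nc(Nc3cccc(OC)c3)nc3c2CSCC3)c1`) gives 48900 nM as the only actual number in this small set. Compound 2 (`C/C=C/C(=O)Nc1cccc(Oc2nc(Nc3cccc(OC)c3)nc3c2CSCC3)c1`) reads > 50000 nM as a limit of the assay. Compound 3 (`CCC/C=C/C(=O)Nc1cccc(Oc2nc(Nc3cccc(OC)c3)nc3c2CSCC3)c1`) likewise reads > 50000 nM as a limit. The set thus rests largely on the limit of > 50000 nM in this assay, at which 2 of the 3 values shown sit, and compound 1 cannot be ranked against its two neighbours.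

Compound 4 (`C=CC(=O)Nc1cccc(Oc2nc(Nc3ccc(OC)cc3)nc3c2CSCC3)c1`) carries 4-methoxyphenyl in place of 3-methoxyphenyl on a nitrogen on an aromatic ring and keeps everything else in the core of compound 1. The measured steps concern a different change. Prop-1-en-1-yl in place of vinyl on a carbonyl carbon gives an at least 1.0-fold higher number from compound 1 to compound 2 (0.00 log units; that floor lies within the scatter) and pent-1-en-1-yl in that place gives an at least 1.0-fold higher number from compound 1 to compound 3 (0.00 log units; that floor lies within the scatter) as the second step. Neither touches the methoxyphenyl group, so they bear on compound 4 only indirectly, and neither shows a change beyond the scatter. No step beyond the scatter is therefore expected in this assay for the new change. The expected step is a 1.2-fold lower number from compound 1 to compound 4 (0.09 log units; within the scatter) and would stay within the scatter. Compound 4 is estimated at 40000 nM with an expected range from 15000 nM to 60000 nM and may also be expected to return only a limit.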

Compound 4, half-maximal inhibitory concentration: > 50000 nM
Compound 4: no number, only a limit; the forecaster's own chance of this, stated with the estimate: 40%; middle value at least 1.2-fold (0.09 log units) away from the limit.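

In this assay, compound 4 reads > 50000 nM, which is a limit of the assay and not a number. This is the first change shown on the aromatic ring carried by the nitrogen rather than on the carbonyl carbon, and 4-methoxyphenyl in place of 3-methoxyphenyl gives an at least 1.0-fold higher number from compound 1 to compound 4 (0.00 log units; that floor lies within the scatter), so this position, like the carbonyl carbon, shows no step beyond the scatter. The result adds a third compound whose value cannot be ranked against compound 1, and the size of this step stays unknown because the reading ends at the assay's limit: the limit of > 50000 nM in this assay, at which 3 of the 4 values shown sit.

The compounds shown leave open how far compound 4 actually lies from compound 1, and whether moving the methoxy group has any effect on the read-out at all. They also leave open whether a different group on that nitrogen, such as a phenyl ring carrying an amine or a carboxylic acid, or a longer chain in place of the methoxy group, would give a measurable number in this assay instead of another limit.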